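The source may hold more compounds than are shown below. What is called first, only, known or untested is meant among the compounds shown, and "the series" means these compounds.

In a physicochemical assay for acid dissociation, compound 3 `COc1ccc(-c2ccc3c(NCCCNCc4ccco4)ccnc3c2)cc1` gives 9.47. Compound 1 `COc1cccc(CNCCCNc2ccnc3cc(Cc4ccccc4)ccc23)c1O` gives 9.47, and compound 2 `Fc1ccc(Oc2ccc3c(NCCCNCc4ccco4)ccnc3c2)cc1` gives 9.28. Compound 3 therefore stands level with compound 1 at the digits shown, the two together the highest of the three, while compound 2 lies within the scatter of both. Within the data shown here, the single measured step, a number 0.19 log units higher from compound 2 to compound 3 (within the scatter), stays within the scatter. Compound 4 `COc1ccc(-c2ccc3c(NCCCNCc4cccc(OC)c4O)ccnc3c2)cc1` differs from compound 3 by 2-hydroxy-3-methoxyphenyl in place of furan-2-yl on a saturated chain carbon bound to an amine nitrogen. Among the measured compounds shown here, no measured step alters this part of the molecule alone, but compound 1 already carries the 2-hydroxy-3-methoxybenzyl group and sits level with compound 3. The expected step, a number 0.03 log units higher from compound 3 to compound 4 (within the scatter), is accordingly none beyond the scatter. Compound 4 is estimated at 9.5, between 9.2 and 9.8.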

Compound 4, acid dissociation constant: 9.47
For compound 4 the middle estimate is 0.03 log units above the measured one, and the stated range covers the measured number.
By their numbers in this assay, from the lowest: compounds 2, 1, 3 and 4 (each within the scatter of the next).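

Among these compounds, putting 2-hydroxy-3-methoxyphenyl in place of furan-2-yl on a saturated chain carbon bound to an amine nitrogen gives no change at the digits printed from compound 3 to compound 4 (within the scatter) in this assay and is the first measured exchange at this position. Likewise, 4-methoxyphenyl in place of benzyl on an aromatic carbon gives no change at the digits printed from compound 1 to compound 4 (within the scatter) and shows that this exchange, too, stays within the scatter when the 2-hydroxy-3-methoxybenzyl group is present. No supporting evidence bears on this result. Still open, as far as these compounds go, is whether a carboxylic acid or a second amine at this position would move the number beyond the scatter.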